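The source may hold more compounds than are shown below. What is called first, only, known or untested is meant among the compounds shown, and "the series" means these compounds.

The measured compounds in a functional assay on MDA-MB-231 cells (Homo sapiens) for cytotoxicity, read by MTT assay, with a stated time of 48 h; on this read-out higher numbers stand for weaker inhibition and lower numbers for stronger inhibition:

Compound 1 `COC(=O)Cn1cc(CO[C@H]2CC(=O)[C@@H]3OC[C@H]2O3)nn1` gives 21300 nM.
Compound 2 `CCCCCCCCn1cc(CO[C@H]2CC(=O)[C@@H]3OC[C@H]2O3)nn1` gives only a limit of this assay, > 50000 nM.
Compound 3 `O=C1C[C@H](OCc2cn(-c3ccccc3)nn2)[C@H]2CO[C@@H]1O2` gives 25200 nM.

Compound 1 has the lowest of the two plain numbers, and the step of a 1.2-fold higher number from compound 1 to compound 3 (0.07 log units; within the scatter) shows that compound 3 sits within the usual scatter of it. The third value is a limit, not a number (the limit of > 50000 nM in this assay, at which 1 of the 3 values shown sits).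

Compound 4 `CCCCn1cc(CO[C@H]2CC(=O)[C@@H]3OC[C@H]2O3)nn1` differs from compound 1 by propyl in place of methoxycarbonyl on a saturated chain carbon bound to an aromatic nitrogen. For the measured compounds named here, two measured steps bear on this change. The step of an at least 2.3-fold higher number from compound 1 to compound 2 (0.37 log units; beyond the scatter) put a longer chain of the same kind in the same place and weakened inhibition. The step of a 1.2-fold higher number from compound 1 to compound 3 (0.07 log units; within the scatter) replaced the whole group on the aromatic nitrogen with phenyl and stayed within the scatter. Propyl is a shorter chain than the heptyl of compound 2, so a smaller move in the same direction seems likely, though it may not clear the scatter. Compound 4 is therefore expected to give about 32000 nM, within a range from 15000 nM to 60000 nM. The expected step is a 1.5-fold higher number from compound 1 to compound 4 (0.18 log units; within the scatter).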

Compound 4, half-maximal inhibitory concentration: 27900 nM
The estimate for compound 4 lay 1.1-fold (0.06 log units) above the measured number; measured number inside the range.
By their numbers in this assay, from the lowest: compounds 1, 3 and 4 (each within the scatter of the next). At a limit, above all of these: compound 2.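

In this assay, a plain butyl chain can stand on the aromatic nitrogen in place of the ester-bearing group or the phenyl without clearing the scatter: a 1.3-fold higher number from compound 1 to compound 4 (0.12 log units; within the scatter), and a 1.1-fold higher number from compound 3 to compound 4 (0.04 log units; within the scatter). The weaker result for octyl in compound 2 therefore does not extend to butyl, although the shortening from octyl to butyl gives only an at least 1.7-fold lower number from compound 2 to compound 4 (0.25 log units; that floor lies within the scatter). Compound 2 stands at a limit, not a plain number: the limit of > 50000 nM in this assay, at which 1 of the 4 values shown sits.

The compounds shown leave open where between butyl and octyl the numbers begin to part, and whether a hexyl chain would sit with compound 4 or with compound 2. Also open, from the compounds shown here alone, is how an amine or a carboxylic acid at the end of the chain would read in this assay.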